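Compound 2 and the step to compound 4

A few compounds are considered here, and "the series" means these few. Any claim that something is new, unique, unknown or untested is made for them only; others in the source may bear on it.

Measured in an in vitro ADME assay on microsomes (Homo sapiens) for metabolic stability; on this read-out higher numbers stand for a longer-lived compound and lower numbers for a shorter-lived compound:
- compound 1 `CCc1nc(NC(CC)CC)c(Cl)nc1-c1ccc(Cl)cc1Cl`: 0.167 h
- compound 2 `CCc1nc(-c2ccc(Cl)cc2Cl)c(CC)nc1NC(COC)COC`: 0.15 h
- compound 3 `CCOc1nc(-c2ccc(Cl)cc2Cl)c(CC)nc1NC(CC)CC`: 2 h

Compound 2, at 0.15 h, sits within the scatter of compound 1, and both lie well short of compound 3. Compound 4 `CCc1nc(-c2ccc(Cl)cc2Cl)c(CC)nc1CC(CC)CC` differs from compound 2 as follows: 2-ethylbutyl in place of (2-methoxy-1-(methoxymethyl)ethyl)amino on an aromatic carbon. For the measured compounds named here, the one measured step, a 12-fold higher number from compound 1 to compound 3 (1.08 log units; beyond the scatter), is large, but it is ethoxy in place of chloro, a different change, so it gives little guidance here. Going by the values given here, no measured step touches this amino group. No step beyond the scatter is therefore expected in this assay, and neither direction is favoured. The estimated step is no change at the digits printed from compound 2 to compound 4 (within the scatter). Compound 4 is expected at 0.15 h, within an estimated range of 0.05 h to 0.5 h.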

Compound 4, half-life: 0.217 h
For compound 4 the middle estimate is 1.4-fold (0.16 log units) below the measured one, within the range that was stated.
By their numbers in this assay, from the lowest: compounds 2, 1 and 4 (each within the scatter of the next); then compound 3.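

In this assay, 2-ethylbutyl in place of the (2-methoxy-1-(methoxymethyl)ethyl)amino group gives a 1.4-fold higher number from compound 2 to compound 4 (0.16 log units; within the scatter), a step within the scatter. This shows that the position next to the ring nitrogen tolerates losing the nitrogen, both oxygens and the hydrogen-bond donor of that group with no change beyond the scatter. Nothing at hand accounts for this result.

Still open, on these data alone, is whether a shorter chain such as propyl, or a primary amine, at this position would leave the number just as close.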